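Aryl exchange on compound 2: working notes

This account rests on a few compounds, and the source may have more. Where it says the series, first, only, none or still open, it means among the compounds named here.

- compound 1 `COc1cc2c(cc1CCC(C)C)C(=O)C[C@@H](c1ccc(O)cc1)O2` gives 78%
- compound 2 `COc1ccc([C@@H]2C/C(=N/OCc3cn(-c4ccc(Cl)cc4C)nn3)c3cc(CC=C(C)C)c(OC)cc3O2)cc1` gives 49%

In a functional assay on PC-3 cells (Homo sapiens) for inhibition, read by sulforhodamine B assay, with a stated time of 48 h, tested at 50 uM (on this read-out higher numbers stand for more inhibition of growth at the one concentration tested and lower numbers for less inhibition of growth), compound 2 holds the lower of the two numbers, with compound 1 at 78% beyond the scatter above it. Compound 3 `COc1ccc([C@@H]2C/C(=N/OCc3cn(-c4cc(OC)c(OC)c(OC)c4)nn3)c3cc(CC=C(C)C)c(OC)cc3O2)cc1` carries 3,4,5-trimethoxyphenyl in place of 4-chloro-2-methylphenyl on an aromatic nitrogen in the frame of compound 2. Going by the values given here, no measured step covers this exchange, so no step beyond the scatter is expected in this assay and no direction is assumed. The estimated change is a number 3 percentage points higher from compound 2 to compound 3 (within the scatter) and remains within the scatter. As an estimate, compound 3 is expected at 52% within a range from 32% to 72% in this read-out.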

Compound 3, percent growth inhibition at one concentration: 36%
The estimate for compound 3 lay 16 percentage points above the measured number, within the range that was stated.
By their numbers in this assay, from the lowest: compound 3; then compound 2; then compound 1.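

In this assay the exchange of 4-chloro-2-methylphenyl for 3,4,5-trimethoxyphenyl brings a number 13 percentage points lower from compound 2 to compound 3 (beyond the scatter) and so shows that the aryl group on the aromatic nitrogen influences the read-out. The aryl group with three methoxy groups gives the lower number of this pair. No measurement at hand bears on the reason for this step.

As far as these compounds go, the two aryl groups differ in several substituents at once, so the share of the chlorine, the methyl and each methoxy group in the step stays open. From the compounds shown here alone, how an amine or a carboxylic acid on this aryl ring would read also remains open.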